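A few compounds are considered here, and "the series" means these few. Any claim that something is new, unique, unknown or untested is made for them only; others in the source may bear on it.

In a functional assay on LNCaP cells (Homo sapiens) for cytotoxicity, read by MTT assay, with a stated time of 72 h (a higher number here means a weaker inhibitor, a lower number a stronger inhibitor), compound 1 `COc1cc(OC)cc(/C(=C\c2cn(C(C)=O)c3ccc(OCc4ccccc4)cc23)C(=O)O)c1` gives 26100 nM and compound 3 `COc1cccc(/C(=C\c2cn(C(C)=O)c3ccc(OCc4ccccc4)cc23)C(=O)O)c1` gives 65100 nM. Compound 2 `CC(=O)n1cc(/C=C(/C(=O)O)c2ccc(Cl)cc2)c2cc(OCc3ccccc3)ccc21` reaches only the limit of this assay, > 100000 nM. Compound 3 thus holds the highest of the two numbers; the step of a 2.5-fold higher number from compound 1 to compound 3 (0.40 log units; beyond the scatter) set it apart from compound 1, while the step of an at least 1.5-fold lower number from compound 2 to compound 3 (0.18 log units; that floor lies within the scatter). Compound 4 `COc1ccccc1/C(=C\c1cn(C(C)=O)c2ccc(OCc3ccccc3)cc12)C(=O)O` differs from compound 3 by 2-methoxyphenyl in place of 3-methoxyphenyl on a double-bonded chain carbon bound to a carbonyl carbon and a double-bonded chain carbon; the two have the same atoms, joined differently. For the measured compounds named here, no measured step compares a 2-methoxyphenyl with a 3-methoxyphenyl, and the steps that exchanged whole aryl groups were modest at most. The step from compound 3 to compound 4 is therefore expected to stay within the scatter, a 1.1-fold lower number from compound 3 to compound 4 (0.04 log units; within the scatter). Compound 4 is estimated at 60000 nM, between 25000 nM and 150000 nM.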

Compound 4, half-maximal inhibitory concentration: 48500 nM
For compound 4 the middle estimate is 1.2-fold (0.09 log units) above the measured one; low and high end bracket the measured number.
By their numbers in this assay, from the lowest: compounds 1, 4 and 3 (each within the scatter of the next, the first and the last beyond it). At a limit, above all of these: compound 2.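

Exchanging 3-methoxyphenyl for 2-methoxyphenyl on this double-bonded chain carbon barely registers in this assay, with a 1.3-fold lower number from compound 3 to compound 4 (0.13 log units; within the scatter). The 3,5-dimethoxyphenyl group also shows no clear edge over the 2-methoxyphenyl group, with a 1.9-fold higher number from compound 1 to compound 4 (0.27 log units; within the scatter). Against the 4-chlorophenyl group, whose reading is only a limit, 2-methoxyphenyl gives a floor beyond the scatter, with an at least 2.0-fold lower number from compound 2 to compound 4 (0.31 log units; beyond the scatter): the limit of > 100000 nM in this assay, at which 1 of the 4 values shown sits.

On these data alone, what a 4-methoxyphenyl or an aminophenyl group would give on this carbon stays open. So does whether any aryl group here could bring the number far lower.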